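Replacing a sulfonamide arm with a methylphenyl ring

This account rests on a few compounds, and the source may have more. Where it says the series, first, only, none or still open, it means among the compounds named here.

Compound 2, `O=C1O[C@H]([C@@H](O)Cn2cc(CNS(=O)(=O)c3ccc(F)cc3)nn2)C(OCc2ccccc2)=C1OCc1ccccc1`, is one of two compounds with a numerical result in an ADME assay on HFF cells (Homo sapiens) for cytotoxicity, read by MTT assay, with a stated time of 72 h; a lower number here means a stronger inhibitor, a higher number a weaker inhibitor. In this assay compound 2 gives 30 nM, the higher of the two numbers; its nearest neighbour is compound 1, `O=C1O[C@H]([C@@H](O)Cn2cc(CNS(=O)(=O)c3ccc(Cl)cc3F)nn2)C(OCc2ccccc2)=C1OCc1ccccc1`, which in this assay gives 20 nM. For the measured compounds named here, the only measured step between them, a 1.5-fold higher number from compound 1 to compound 2 (0.18 log units; within the scatter), is within the scatter. Compound 3, `CCCCCc1ccc(-c2cn(C/C=C3\OC(=O)C(OCc4ccccc4)=C3OCc3ccccc3)nn2)cc1`, gives in this assay only the limit > 100000 nM, so no number is known for it.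

The unmeasured compound 4, `Cc1ccc(-c2cn(C[C@H](O)[C@H]3OC(=O)C(OCc4ccccc4)=C3OCc3ccccc3)nn2)cc1`, differs from compound 2 in one place: 4-methylphenyl in place of (((4-fluorophenyl)sulfonyl)amino)methyl on an aromatic carbon. Going by the values given here, no measured step covers a change of this kind; the single step between compounds 1 and 2 swaps one ring on the sulfonyl sulfur for another and stays within the scatter, so it says little here. Compound 3 carries a substituted phenyl ring directly on the same five-membered ring, but it differs from compound 4 elsewhere as well, so only its limit can be noted.

The step from compound 2 to compound 4 is therefore expected to weaken inhibition markedly, as a 670-fold higher number from compound 2 to compound 4 (2.82 log units; beyond the scatter). Compound 4 is estimated to give 20000 nM, in a range from 2000 nM to 100000 nM.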

Compound 4, half-maximal inhibitory concentration: > 100000 nM
Compound 4: no number, only a limit; the forecaster's own chance of this, stated with the estimate: 40%; middle value at least 5.0-fold (0.69 log units) from the limit.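

The step between compounds 1 and 2 changed only the ring on the sulfonyl sulfur and stayed within the scatter, whereas exchanging the whole (((4-fluorophenyl)sulfonyl)amino)methyl arm for 4-methylphenyl on the aromatic carbon gives, in this assay, an at least 3300-fold higher number from compound 2 to compound 4 (3.52 log units; beyond the scatter). For this pair, what sits on this aromatic carbon therefore decides between a value in the low nanomolar range and no measurable number, a far larger difference than the ring swap on the sulfur revealed. Compound 4 has only a limit, not a number, so the true size of this step cannot be read, because the result sits at the top of what the assay reports: the limit of > 100000 nM in this assay, at which 2 of the 4 values shown sit.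

The compounds shown leave open which part of the departing arm matters, since the sulfonyl group, its nitrogen and the linking carbon all go in one change. An amine such as aminomethyl on the same aromatic carbon, or an amide in place of the sulfonamide link, would begin to separate these parts.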